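From 1,3-thiazol-5-yl to thiophen-3-yl on the carbonyl

The compounds below may be only part of what the source reports. "The series", "measured", "known", "first", "only" and "open" are said of these compounds alone.

Within the data shown here, in a functional assay on DMS-273 cells (Homo sapiens) for inhibition, read by colorimetric assay and sulforhodamine B assay, with a stated time of 48 h (a higher number here means a weaker inhibitor of growth, a lower number a stronger inhibitor of growth), compound 3 (`CCCCCCCCCCCC[C@@H](O)[C@H]1CC[C@H]([C@H](O)CCCCCCCCCCNC(=O)c2cncs2)O1`) gives 19100 nM, the lowest of the three numbers so far. Compound 1 (`CCCCCCCCCCCC[C@@H](O)[C@H]1CC[C@H]([C@H](O)CCCCCCCCCCNC(=O)c2ccco2)O1`) gives 39800 nM and compound 2 (`CCCCCCCCCCCC[C@@H](O)[C@H]1CC[C@H]([C@H](O)CCCCCCCCCCNC(=O)c2ccoc2)O1`) gives 100000 nM.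

Compound 4 (`CCCCCCCCCCCC[C@@H](O)[C@H]1CC[C@H]([C@H](O)CCCCCCCCCCNC(=O)c2ccsc2)O1`) has thiophen-3-yl in place of 1,3-thiazol-5-yl on a carbonyl carbon.

All three measured steps change this same group, and all are modest: a 2.5-fold higher number from compound 1 to compound 2 (0.40 log units; beyond the scatter), a 2.1-fold lower number from compound 1 to compound 3 (0.32 log units; beyond the scatter) and a 5.2-fold lower number from compound 2 to compound 3 (0.72 log units; beyond the scatter). The most relevant is the last, since compound 2 carries furan-3-yl, the measured group closest in name to thiophen-3-yl. No thiophene has been measured in this series, so that comparison is only a rough guide. A modest step toward a higher number in this assay is expected, smaller than the gap between compound 2 and compound 3. The expected step is a 2.1-fold higher number from compound 3 to compound 4 (0.32 log units; beyond the scatter). For compound 4 the estimated value is 40000 nM, with an expected range of 13000 nM to 100000 nM.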

Compound 4, concentration for 50% growth inhibition: 2000 nM
Compound 4: middle estimate off by 20-fold (1.30 log units), on the high side; the whole stated range lies above it.
By their numbers in this assay, from the lowest: compound 4; then compound 3; then compound 1; then compound 2.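

In this assay, among these compounds, the group on the carbonyl carbon has far more reach than the earlier compounds suggested: a 9.6-fold lower number from compound 3 to compound 4 (0.98 log units; beyond the scatter) and a 20-fold lower number from compound 1 to compound 4 (1.30 log units; beyond the scatter) and a 50-fold lower number from compound 2 to compound 4 (1.70 log units; beyond the scatter) put thiophen-3-yl at the lowest number of the four. The step from 1,3-thiazol-5-yl keeps the count of 5 heavy atoms and one five-membered aromatic ring, so a swap that only takes the ring from 2 hetero atoms to 1 is enough to shift the number this far. No measurement at hand accounts for the size of these steps.

Going by these compounds, whether thiophen-2-yl or phenyl on the same carbonyl carbon would hold the low number remains open. So does whether thiophen-3-yl keeps its lead with a shorter chain on the amide nitrogen.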